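Lengthening the acid chain on a compound at the limit

The source may hold more compounds than are shown below. What is called first, only, known or untested is meant among the compounds shown, and "the series" means these compounds.

Measured in a functional assay for inhibition, with Homo sapiens as the target; a higher number here means a weaker inhibitor, a lower number a stronger inhibitor:
compound 1 `O=C(O)CCCCCCCn1nc(-c2ccccc2)c(-c2ccccc2)c1-c1ccccc1`: 3400 nM
compound 2 `O=C(O)CCCCCCCCCn1nc(-c2ccccc2)c(-c2ccccc2)c1-c1ccccc1`: 5500 nM
compound 3 `O=C(O)CCCCCCCn1cc(-c2ccccc2)c(-c2ccccc2)n1`: > 85000 nM (a limit, not a number)

For compound 3 the entry > 85000 nM is a limit of the assay and not a number. Going by these compounds, compound 3 thus stands at the limit of > 85000 nM in this assay, at which 1 of the 3 values shown sits, so its exact place on the scale is unknown. Within the data shown here, the one measured step leading to it, an at least 25-fold higher number from compound 1 to compound 3 (1.39 log units; beyond the scatter), is large and beyond the scatter, and it comes with hydrogen in place of phenyl on an aromatic carbon.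

Compound 4 `O=C(O)CCCCCCCCCn1cc(-c2ccccc2)c(-c2ccccc2)n1` keeps the core of compound 3 and changes only the acid chain: 2-carboxyethyl in place of carboxy on a saturated chain carbon, seven bonds along the chain from an aromatic nitrogen. That is 2-carboxyethyl in place of carboxy on a saturated chain carbon, seven bonds along the chain from an aromatic nitrogen. The same exchange has been measured once, on the core of compound 1, and there it gave a 1.6-fold higher number from compound 1 to compound 2 (0.21 log units; within the scatter), which lies within the scatter. On this single precedent, no step beyond the scatter is expected in this assay, in either direction. The expected step is a number no higher from compound 3 to compound 4 (the limit leaves the size open), an estimate that can only be loose given where compound 3 stands. Compound 4 is estimated at 85000 nM, with an expected range from 30000 nM to 200000 nM, and the assay may well report only a limit again.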

Compound 4, half-maximal inhibitory concentration: > 81000 nM
Compound 4 ended at the assay's limit; the forecaster's own chance of this, stated with the estimate: 60%; the middle value does not contradict the limit.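

In this assay compound 4 gives > 81000 nM, which is a limit of the assay and not a number. Among these compounds, the step from compound 3 to compound 4 cannot be read, so the exchange of carboxy for 2-carboxyethyl, on a saturated chain carbon, seven bonds along the chain from an aromatic nitrogen, has no measured size on this core and its one precedent on the core of compound 1 finds no test here. What the result does add is a second instance of the other change, since hydrogen in place of phenyl on an aromatic carbon gives an at least 14-fold higher number from compound 2 to compound 4 (1.16 log units; beyond the scatter), so the large step now appears with both chain lengths: the same change on two cores in this assay, an at least 25-fold higher number (1.39 log units; beyond the scatter) from compound 1 to compound 3 and an at least 14-fold higher number (1.16 log units; beyond the scatter) from compound 2 to compound 4; the limit leaves it open whether they differ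

The compounds shown leave open where compound 3 and compound 4 truly lie on the scale, and with that whether the chain exchange does anything at all on this core and whether the two large steps differ in size. They also leave open what a methyl group in place of that phenyl on the aromatic carbon would give, and whether an amide in place of the carboxylic acid would keep the numbers of compound 1 and compound 2.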